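Working notes: from compound 2 to compound 4

The compounds below may be only part of what the source reports. "The series", "measured", "known", "first", "only" and "open" are said of these compounds alone.

Going by the values given here, in a functional assay on SK-OV-3 cells (Homo sapiens) for antiproliferative activity, read by MTT assay, with a stated time of 72 h (a higher number here means a weaker inhibitor, a lower number a stronger inhibitor), compound 2 `O=C(CCc1cccc2c1B(O)OC2)Nc1cccc(-c2ccc(F)cc2)c1` gives 93 nM, the lowest of the three numbers measured so far. Compound 1 `O=C(CCc1cccc2c1B(O)OC2)Nc1cccc(Br)c1` gives 540 nM, and compound 3 `O=C(CCc1cccc2c1B(O)OC2)Nc1cccc(-c2ccc(OC(F)(F)F)cc2)c1` gives 560 nM.

Compound 4 `O=C(CCc1cccc2c1B(O)OC2)Nc1cccc(-c2cccc(C(F)(F)F)c2)c1` keeps the shared core and changes only the terminal aryl group: 3-(trifluoromethyl)phenyl in place of 4-fluorophenyl on an aromatic carbon, with 3-(trifluoromethyl)phenyl in place of 4-fluorophenyl on an aromatic carbon.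

Among the compounds with values here, two measured steps bear on this change. The first, a 5.8-fold lower number from compound 1 to compound 2 (0.76 log units; beyond the scatter), came with 4-fluorophenyl in place of bromo, so it shows the gain from installing that group rather than the outcome of altering it. The second, a 6.0-fold higher number from compound 2 to compound 3 (0.78 log units; beyond the scatter), came with trifluoromethoxy in place of fluoro and is the closer guide. Within the data shown here, no measured compound carries 3-(trifluoromethyl)phenyl.

With only a 6.0-fold higher number from compound 2 to compound 3 (0.78 log units; beyond the scatter) as a guide to changes on the 4-fluorophenyl group, a move to a higher number is expected in this assay, probably of somewhat smaller size. The expected step is a 3.2-fold higher number from compound 2 to compound 4 (0.51 log units; beyond the scatter). For compound 4 the estimated value is 300 nM, with an expected range of 90 nM to 900 nM.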

Compound 4, half-maximal inhibitory concentration: 390 nM
The estimate for compound 4 lay 1.3-fold (0.11 log units) below the measured number; the range from low to high includes it.
By their numbers in this assay, from the lowest: compound 2; then compounds 4, 1 and 3 (each within the scatter of the next).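

In this assay, 3-(trifluoromethyl)phenyl in place of 4-fluorophenyl gives a 4.2-fold higher number from compound 2 to compound 4 (0.62 log units; beyond the scatter), so the low number of compound 2 does not carry over to this other substituted phenyl group. Set against the bromo group, 3-(trifluoromethyl)phenyl gives a 1.4-fold lower number from compound 1 to compound 4 (0.14 log units; within the scatter), a step within the scatter, so an added aryl ring at this position does not by itself bring the gain seen with 4-fluorophenyl. Nothing available explains either step.

Compound 4 alters both the substituent on the terminal ring and where it sits, so the contribution of each to the step remains unresolved. On these data alone, the response of this position to an unsubstituted phenyl, or to a terminal ring bearing an amine or a carboxylic acid, also remains open.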